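Swapping methyl for hydrogen on a compound at the limit

This account rests on a few compounds, and the source may have more. Where it says the series, first, only, none or still open, it means among the compounds named here.

Compound 3 (`CN1CCc2cccc(c2)Oc2ccc(cc2)CCC1=O`) gives > 100 ug/mL in a functional assay on L1210 cells (Mus musculus) for cytotoxicity (a higher number here means a weaker inhibitor, a lower number a stronger inhibitor), and this value is a limit of the assay, not a number. Compound 3 therefore stands at the limit of > 100 ug/mL in this assay, at which 1 of the 3 values shown sits. Compound 4 (`O=C1CCc2ccc(cc2)Oc2cccc(c2)CCN1`) differs from it by one change: hydrogen in place of methyl on an amide-type nitrogen in a ring. Hydrogen replaces methyl on an amide-type nitrogen in a ring.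

For the measured compounds named here, only one measured step bears on this swap, and it comes from a different core. In this assay, compound 1 (`COC(=O)[C@@H]1Cc2ccc(OC)c(c2)Oc2ccc(cc2)C[C@H](N(C)C(=O)OCc2ccccc2)C(=O)N1C`) gives 0.04 ug/mL, and compound 2 (`COC(=O)[C@@H]1Cc2ccc(OC)c(c2)Oc2ccc(cc2)C[C@H](N(C)C(=O)OCc2ccccc2)C(=O)N1`) gives 0.05 ug/mL. The same swap there amounts to a 1.3-fold higher number from compound 1 to compound 2 (0.10 log units; within the scatter). On the evidence of compound 2 and that step, no change beyond the scatter is expected in this assay, and so no direction is expected either. Going by the values given here, the step comes from a much more elaborate core than that of compound 3, and no measured pair shows the swap on a compound sitting at a limit. The transfer is therefore uncertain, and the most likely report for the new compound is again only a limit. The expected step is a step that the limit leaves unreadable from compound 3 to compound 4. For compound 4 the estimated value is 150 ug/mL, with an estimated range from 50 ug/mL to 400 ug/mL.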

Compound 4, half-maximal inhibitory concentration: > 100 ug/mL
Compound 4: a limit, no number; the forecaster's own chance of this, stated with the estimate: 85%; the middle value lies beyond the limit too.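

In this assay compound 4 gives > 100 ug/mL, a limit of the assay and not a number. Compound 3 also sits at a limit, so no step can be read between compound 3 and compound 4: the limit of > 100 ug/mL in this assay, at which 2 of the 4 values shown sit. The compounds shown leave open whether hydrogen in place of methyl changes the read-out at all on this core.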